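A few compounds are considered here, and "the series" means these few. Any claim that something is new, unique, unknown or untested is made for them only; others in the source may bear on it.

Compound 3 `CC(C)c1cccc(OC(=O)c2cn(-c3ccccc3)nc2-c2ccncc2)c1` has no single number in a functional assay on HL-60 cells (Homo sapiens) for cytotoxicity, read by MTT assay, with a stated time of 48 h; on this read-out higher numbers stand for weaker inhibition and lower numbers for stronger inhibition: in this assay compound 3 gives "nd(insoluble)" (no result reported). Compound 2 `CCc1ccc(OC(=O)c2cn(-c3ccccc3)nc2-c2ccncc2)cc1` likewise returns "nd(insoluble)" (no result reported) in this assay. Compound 1 `O=C(NCc1ccccc1)c1cn(-c2ccccc2)nc1-c1ccncc1` gives > 100000 nM in this assay, which is a limit of the measurement and not a number. That limit is the only entry in this assay with a figure attached (the limit of > 100000 nM in this assay, at which 1 of the 3 values shown sits). Compound 4 `O=C(O)c1cn(-c2ccccc2)nc1-c1ccncc1` is not yet measured; it differs from compound 3 by hydrogen in place of 3-isopropylphenyl on an oxygen next to a carbonyl group. No step between measured compounds exists in this assay, so no size or direction of change can be drawn from the data shown; the expectation is a further limit rather than a step beyond the scatter. Compound 4 is expected at 150000 nM in this assay, within 40000 nM to 500000 nM.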

Compound 4, half-maximal inhibitory concentration: > 100000 nM
Compound 4: only a limit was reported; the forecaster's own chance of this, stated with the estimate: 75%; the middle value is on the limit's open side.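

Compound 1 and compound 4 each carry only a limit, so no step between them can be read: the limit of > 100000 nM in this assay, at which 2 of the 4 values shown sit.

The compounds shown leave open whether any group on this carbonyl carbon gives a measurable figure in this assay.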